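The compounds below may be only part of what the source reports. "The series", "measured", "known", "first", "only" and "open" are said of these compounds alone.

Measured so far in a functional assay on MGC-803 cells (Homo sapiens) for cytotoxicity, read by MTT assay, with a stated time of 48 h; on this read-out lower numbers stand for stronger inhibition and higher numbers for weaker inhibition:
- compound 1 `CC1CCCCN1CC(=O)N1N=C(c2cc3ccccc3oc2=O)CC1c1ccccc1`, compound 1 gives "not active" (no number reported)
- compound 2 `CC1CCCN(CC(=O)N2N=C(c3cc4ccccc4oc3=O)CC2c2ccccc2)C1`, compound 2 gives "not active" (no number reported)
- compound 3 `CCN(CC)C1CCN(CC(=O)N2N=C(c3cc4ccccc4oc3=O)CC2c2ccccc2)CC1`, compound 3 gives 32400 nM

Among the compounds with values here, compound 3 is the only member of the series with a numerical value in this assay; compounds 1 and 2 carry no number, so no step between measured compounds can be given. Compound 4 `NC(=O)C1CCN(CC(=O)N2N=C(c3cc4ccccc4oc3=O)CC2c2ccccc2)CC1` is the next entry. Relative to compound 3 the change is carbamoyl in place of diethylamino on a saturated ring carbon, in words carbamoyl in place of diethylamino on a saturated ring carbon. Within the data shown here, with no comparable step available, the expectation is a step from compound 3 to compound 4 of a 1.2-fold higher number from compound 3 to compound 4 (0.09 log units; within the scatter), that is no change beyond the scatter. Compound 4 is accordingly estimated at 40000 nM, with a range from 14000 nM to 120000 nM.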

Compound 4, half-maximal inhibitory concentration: 21500 nM
Compound 4: middle estimate off by 1.9-fold (0.27 log units), on the high side; measured number inside the range.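

In this assay, carbamoyl in place of diethylamino on a saturated ring carbon gives a 1.5-fold lower number from compound 3 to compound 4 (0.18 log units; within the scatter), so this position carries either group without a separation beyond the scatter. Steps to the two compounds without a number cannot be read. No measurement here accounts for this result.

On these data alone, whether a carboxylic acid or a primary amine on the same ring carbon would give a step beyond the scatter stays open. So does whether a longer chain ending in carbamoyl would do so.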